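This account rests on a few compounds, and the source may have more. Where it says the series, first, only, none or still open, it means among the compounds named here.

Values in a functional assay on A549 cells (Homo sapiens) for cytotoxicity, read by MTT assay, with a stated time of 48 h; on this read-out lower numbers stand for stronger inhibition and higher numbers for weaker inhibition:
- compound 1 `COc1cc([C@H]2C[C@]2(CO)C(=O)Nc2ccccc2Cl)cc(OC)c1OC`: 36700 nM
- compound 2 `CCOC(=O)[C@]1(C(=O)Nc2ccccc2Cl)C[C@@H]1c1cc(OC)c(OC)c(OC)c1`: 50900 nM
- compound 3 `COc1cc([C@H]2C[C@]2(CO)C(=O)Nc2ccccc2)cc(OC)c1OC`: > 100000 nM (a limit, not a number)

Going by the values given here, only two true numbers exist in this assay, and they cannot be told apart: a 1.4-fold higher number from compound 1 to compound 2 (0.14 log units; within the scatter). Compound 1 therefore shares the low end of the values with compound 2. Compound 3 gives only a limit: the limit of > 100000 nM in this assay, at which 1 of the 3 values shown sits. Removing the chloro group gives a clearer change: an at least 2.7-fold higher number from compound 1 to compound 3 (0.43 log units; beyond the scatter).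

Compound 4 `COc1cc([C@@H]2C[C@@]2(CO)C(=O)Nc2ccccc2Cl)cc(OC)c1OC` is the mirror image of compound 1: the two compounds have the same atoms and bonds and differ only in configuration as drawn: 2 of 2 stereo elements differ (all stereocentres are inverted: mirror images); a stereocentre at a saturated ring carbon is drawn R in compound 1 and S in compound 4; a stereocentre at a saturated ring carbon is drawn S in compound 1 and R in compound 4. Neither measured step alters configuration, so neither gives a direct size for this inversion. Among the compounds with values here, they show only that one substituent swap stayed within the scatter, while the other went beyond it. Within the data shown here, with no measured stereochemical pair, the direction stays open, and the central expectation is no shift beyond the scatter. The expected step is a 1.2-fold higher number from compound 1 to compound 4 (0.09 log units; within the scatter), with a wide margin. Compound 4 is estimated at 45000 nM, with an expected range of 18000 nM to 100000 nM.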

Compound 4, half-maximal inhibitory concentration: 11400 nM
Compound 4: middle estimate off by 3.9-fold (0.60 log units), on the high side; the whole stated range lies above it.
By their numbers in this assay, from the lowest: compound 4; then compounds 1 and 2 (each within the scatter of the next). At a limit, above all of these: compound 3.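

In this assay the step of a 3.2-fold lower number from compound 1 to compound 4 (0.51 log units; beyond the scatter) puts a first measured size on configuration at the two saturated ring carbons. The earlier steps shown here changed substituents only and gave no reading on this inversion. The step can be assigned to configuration alone because no atom or bond changes within the pair: the fact that compounds 1 and 4 differ only in the configuration as drawn.

On these data alone, both stereocentres invert together in this pair, so the share of each one stays open, as does the value of a compound with only one of them inverted. Also open, as far as these compounds go, is whether the same inversion gives a step of this size when a carboxylic acid or an amine stands in place of the hydroxymethyl group, or in the mirror images of compound 2 and compound 3.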